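Swapping an Octyl Chain for a Phenyl Ring

The source may hold more compounds than are shown below. What is called first, only, known or untested is meant among the compounds shown, and "the series" means these compounds.

Of the compounds shown here, three built on one shared core have been tested in a functional assay on the whole organism with Rattus norvegicus as the target; on this read-out lower numbers stand for an effect already at smaller amounts and higher numbers for an effect only at larger amounts of compound. Compound 1 `CCCCc1ccc(-c2c(C)[nH]c(=O)n2C)cc1` gives 0.1 mg/kg in this assay. Compound 2 `CCCCCCCCOc1ccc(-c2c(C)[nH]c(=O)n2C)cc1` gives 30 mg/kg, and compound 3 `CCCCCCCCOc1ccc(-c2c(C)[nH]c(=O)n2C2CCCCC2)cc1` gives 30 mg/kg. Compound 3 therefore stands level with compound 2 at the top of the range, while compound 1 lies far lower; compounds 2 and 3 differ only in the group on the aromatic nitrogen, and the step of no change at the digits printed from compound 2 to compound 3 (within the scatter) shows that exchange made no difference beyond the scatter.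

Compound 4 `Cc1[nH]c(=O)n(C2CCCCC2)c1-c1ccc(Oc2ccccc2)cc1` arises from compound 3 by a change on the oxygen: phenyl in place of octyl on an oxygen on an aromatic ring. Cut one bond further out, octyloxy becomes phenoxy. Going by the values given here, no measured step touches this position, so the single step that bears on the series, no change at the digits printed from compound 2 to compound 3 (within the scatter), says nothing about it; the gap between compound 1 and compound 2 involves two changes at once and cannot be untangled. The expectation is therefore loose: compound 4 is estimated at 3 mg/kg, within 0.3 mg/kg to 30 mg/kg, meaning an expected step of a 10-fold lower number from compound 3 to compound 4 (1.00 log units; beyond the scatter).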

Compound 4, minimum effective dose: 0.1 mg/kg
Beside the measured number, compound 4's estimate is 30-fold (1.48 log units) above it; measured number below the stated range.
By their numbers in this assay, from the lowest: compounds 1 and 4 (each within the scatter of the next); then compounds 2 and 3 (each within the scatter of the next).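

Phenyl in place of octyl on an oxygen on an aromatic ring gives a 300-fold lower number from compound 3 to compound 4 (2.48 log units; beyond the scatter) in this assay and so shows that the result is highly sensitive to the group at this position. Going by these compounds alone, the earlier step of no change at the digits printed from compound 2 to compound 3 (within the scatter) concerned only the group on the aromatic nitrogen, so this is the first measured change at the oxygen and the first step here to go beyond the scatter. No measurement at hand explains the size of this step.

As far as these compounds go, whether the gain comes from having the aromatic ring or from losing the octyl chain stays open, and a hexyl chain or a benzyl group on the same oxygen would help to separate the two. From the compounds shown here alone, it also remains open whether methyl and cyclohexyl on the aromatic nitrogen still read alike with phenoxy in place.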